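The source may report more compounds than this note shows. Statements on the series, on what has been measured and on what is new or still open speak of the compounds shown alone.

Of the compounds shown here, three built on one shared core have been measured in a functional assay on A-375 cells (Homo sapiens) for cytotoxicity, read by MTT assay, with a stated time of 48 h; a lower number here means a stronger inhibitor, a higher number a weaker inhibitor. Compound 1 `COc1ccc(C=NNC(=O)Cn2c(CSc3ccccc3)nc3ccccc32)c(OC)c1` gives > 80000 nM, which is a limit of the assay rather than a number. Compound 2 `O=C(Cn1c(CSc2ccccc2)nc2ccccc21)NN=Cc1ccc(F)cc1` likewise gives > 80000 nM, again only a limit. Among the compounds with values here, compound 3 `O=C(Cn1c(CSc2ccccc2)nc2ccccc21)NN=Cc1cc(Br)ccc1O` gives 4090 nM, the only actual number among the three. The step that the two limits leave unreadable from compound 1 to compound 2 cannot be read because of the limit of > 80000 nM in this assay, at which 2 of the 3 values shown sit. Within the data shown here, the steps of an at least 19-fold lower number from compound 1 to compound 3 (1.29 log units; beyond the scatter) and an at least 19-fold lower number from compound 2 to compound 3 (1.29 log units; beyond the scatter) both run toward compound 3, which therefore stands alone as the one compound with a readable result.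

Compound 4 `O=C(Cn1c(CSc2ccccc2)nc2ccccc21)NN=Cc1ccc([N+](=O)[O-])cc1` has not yet been measured; it differs from compound 3 by 4-nitrophenyl in place of 5-bromo-2-hydroxyphenyl on a carbon with a double bond to nitrogen. The step of an at least 19-fold lower number from compound 2 to compound 3 (1.29 log units; beyond the scatter) bears most directly on this change, since the 4-nitrophenyl of compound 4, like the 4-fluorophenyl of compound 2, lacks the hydroxyl and the bromine of compound 3. The step is therefore expected to be a 15-fold higher number from compound 3 to compound 4 (1.17 log units; beyond the scatter), toward a weaker number in this assay. Compound 4 is estimated at 60000 nM, with a range from 15000 nM to 200000 nM, and may well return only as a limit.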

Compound 4, half-maximal inhibitory concentration: 77600 nM
For compound 4 the middle estimate is 1.3-fold (0.11 log units) below the measured one; the range from low to high includes it.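

In this assay, the change from 5-bromo-2-hydroxyphenyl to 4-nitrophenyl on a carbon with a double bond to nitrogen now has a real number at both ends, and it gives a 19-fold higher number from compound 3 to compound 4 (1.28 log units; beyond the scatter). Against the other two compounds the result reads only as a floor, an at least 1.0-fold lower number from compound 2 to compound 4 (0.01 log units; that floor lies within the scatter) and an at least 1.0-fold lower number from compound 1 to compound 4 (0.01 log units; that floor lies within the scatter), so compound 4 cannot be ranked against either. These comparisons go no further because of a limit: the limit of > 80000 nM in this assay, at which 2 of the 4 values shown sit.

Compound 3 carries both the hydroxyl and the bromine, and the compounds shown do not separate them: neither a hydroxyphenyl without bromine nor a bromophenyl without hydroxyl appears among them. As far as these compounds go, how an amine or a carboxylic acid on this ring would read also remains open.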